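The source may hold more compounds than are shown below. What is called first, only, known or untested is meant among the compounds shown, and "the series" means these compounds.

Measured compounds:
compound 1, `CCCN1CCc2c(cccc2Oc2ncccc2NC(=O)Nc2ccc(OC(F)(F)F)cc2)C1`: 620 nM
compound 2, `CCN1CCc2c(cccc2Oc2ncccc2NC(=O)Nc2ccc(OC(F)(F)F)cc2)C1`: 1700 nM
compound 3, `CC(C)N1CCc2c(cccc2Oc2ncccc2NC(=O)Nc2ccc(OC(F)(F)F)cc2)C1`: 560 nM

All three share one core and differ only in the group carried on the amine nitrogen in the ring. In an assay on HEK293 cells for displacement of a labelled ligand from P2Y purinoceptor 1 (Homo sapiens), read by scintillation counting, with a stated time of 1 h (a higher number here means a weaker inhibitor, a lower number a stronger inhibitor), compound 3 gives the lowest number of the three, but its gap to compound 1 is within the scatter, so the two cannot be ranked; only compound 2 stands clearly apart from it.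

Compound 4, `O=C(Nc1ccc(OC(F)(F)F)cc1)Nc1cccnc1Oc1cccc2c1CCNC2`, has not yet been measured. It differs from compound 3 by hydrogen in place of isopropyl on an amine nitrogen in a ring, so the nitrogen carries no carbon group at all.

Going by the values given here, two measured steps bear on this. Shortening the chain on that nitrogen by one carbon gave a 2.7-fold higher number from compound 1 to compound 2 (0.44 log units; beyond the scatter), and adding a carbon back gave a 3.0-fold lower number from compound 2 to compound 3 (0.48 log units; beyond the scatter), while exchanging one three-carbon group for another gave a 1.1-fold lower number from compound 1 to compound 3 (0.04 log units; within the scatter). Taken together, fewer carbons on this nitrogen have gone with higher numbers, and compound 4 strips the nitrogen bare, a larger removal than either measured step. The expectation is therefore a modest to clear rise in this assay, beyond the scatter, of about a 7.1-fold higher number from compound 3 to compound 4 (0.85 log units; beyond the scatter).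

On that basis compound 4 is estimated at 4000 nM, within a range of 1200 nM to 14000 nM.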

Compound 4, inhibition constant: 3000 nM
For compound 4 the middle estimate is 1.3-fold (0.12 log units) above the measured one; measured number inside the range.
By their numbers in this assay, from the lowest: compounds 3 and 1 (each within the scatter of the next); then compounds 2 and 4 (each within the scatter of the next).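

Replacing the isopropyl group on the amine nitrogen in the ring with hydrogen gives a 5.4-fold higher number from compound 3 to compound 4 (0.73 log units; beyond the scatter) in this assay and doing the same with the propyl group gives a 4.8-fold higher number from compound 1 to compound 4 (0.68 log units; beyond the scatter) so a bare nitrogen clearly gives up ground to either three-carbon group. Replacing the ethyl group with hydrogen gives only a 1.8-fold higher number from compound 2 to compound 4 (0.25 log units; within the scatter) and so compounds 2 and 4 cannot be ranked, which means the number does not climb evenly with each carbon lost: the four compounds fall into two sets, with the clear gap lying between the three-carbon groups and the ethyl group, and no gap resolved between ethyl and hydrogen. No measurement offered here explains why this position behaves in that way.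

Going by these compounds, whether a methyl group on this nitrogen would fall with ethyl and hydrogen or with the three-carbon groups remains open. So does whether a longer chain such as butyl, or a ring such as cyclopropyl, would bring the number lower still or leave it level with compounds 1 and 3.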